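This account rests on a few compounds, and the source may have more. Where it says the series, first, only, none or still open, it means among the compounds named here.

Measured compounds:
compound 1 `O=C1NC(=S)/C(=C/c2cccc(Cl)c2)S1` — 17.6%
compound 2 `O=C1NC(=S)/C(=C/c2ccccc2Cl)S1` — 5.97%
compound 3 `O=C1NC(=S)/C(=C/c2ccc(Cl)c(Cl)c2)S1` — 11%

All three numbers come from a functional assay on HEp-2 cells (Homo sapiens) for cytotoxicity, read by MTT assay, with a stated time of 72 h, tested at 5 ug/mL; a lower number here means less inhibition of growth, a higher number more inhibition of growth at the concentration tested. Compound 1 and compound 3 differ in one place, (chloro in place of hydrogen on an aromatic carbon), and the step is a number 6.6 percentage points lower from compound 1 to compound 3 (within the scatter). Compound 2 and compound 1 hold the same atoms joined differently; the difference between the two cores is not broken down here.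

Compound 4 `O=C1NC(=S)/C(=C/c2c(Cl)cccc2Cl)S1` has not been measured. It arises from compound 2 by chloro in place of hydrogen on an aromatic carbon. This is the same kind of change as from compound 1 to compound 3, not the same: there the entering chloro sits ortho to a chloro group and para to a group of 8 heavy atoms, here meta to a chloro group and ortho to a group of 8 heavy atoms. The step expected in this assay is a number 2 percentage points higher from compound 2 to compound 4 (within the scatter) because a number 6.6 percentage points lower from compound 1 to compound 3 (within the scatter) lies within the scatter. Compound 4 is estimated at 8%, between 0% and 20%.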

Compound 4, percent growth inhibition at one concentration: -2.39%
The estimate for compound 4 lay 10.4 percentage points above the measured number, and the stated range ends above it.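

The chloro in place of hydrogen on an aromatic carbon gives a number 8.4 percentage points lower from compound 2 to compound 4 (within the scatter) in this assay. Set beside the earlier step, the same change shows no difference between the two cores: the same change on two cores in this assay, a number 6.6 percentage points lower (within the scatter) from compound 1 to compound 3 and a number 8.4 percentage points lower (within the scatter) from compound 2 to compound 4, 1.8 percentage points apart, within the scatter of two such steps

This does not show that the change lowers growth inhibition, since each step on its own lies within the scatter, and two cores say nothing about how it would behave on a further core.

The compounds shown carry only chloro on the aromatic ring. Going by these compounds, whether an amine, a methoxy group or a carboxylic acid in its place would move the number beyond the scatter stays open.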